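From ethyl to 2-hydroxyethyl on the shared core

The source may hold more compounds than are shown below. What is called first, only, known or untested is meant among the compounds shown, and "the series" means these compounds.

Going by the values given here, in an ADME assay on MDCKII-LE cells (Canis lupus familiaris) for permeability (on this read-out lower numbers stand for lower permeability and higher numbers for higher permeability), compound 1 `Cc1cnc(NC(=O)c2cc(Oc3cnc(C(=O)N(C)C)nc3)c3cn(C)nc3c2)cn1` gives 11.5 10^-6 cm/s and compound 2 `CCn1cc2c(Oc3ccc(S(C)(=O)=O)cc3)cc(C(=O)Nc3cnc(C)cn3)cc2n1` gives 13.4 10^-6 cm/s, so compound 2 stands within the scatter of the only other measured compound. Compound 3 `Cc1cnc(NC(=O)c2cc(Oc3ccc(S(C)(=O)=O)cc3)c3cn(CCO)nc3c2)cn1` differs from compound 2 by hydroxy in place of hydrogen on a saturated chain carbon, two bonds along the chain from an aromatic nitrogen. Among the compounds with values here, no measured pair shows this change, so the expectation rests on the structural change alone. A downward move somewhat beyond the scatter is expected, an estimated 2.2-fold lower number from compound 2 to compound 3 (0.35 log units; beyond the scatter). For compound 3 the estimated value is 6 10^-6 cm/s, with an expected range of 2.5 10^-6 cm/s to 12 10^-6 cm/s.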

Compound 3, apparent permeability in the MDCKII-LE assay: 6.3 10^-6 cm/s
For compound 3 the middle estimate is 1.1-fold (0.02 log units) below the measured one, within the range that was stated.
By their numbers in the MDCKII-LE assay, from the lowest: compounds 3, 1 and 2 (each within the scatter of the next, the first and the last beyond it).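

Going by these compounds alone, the first step at this chain position shows that ethyl to 2-hydroxyethyl moves the two read-outs in opposite directions. In the MDCKII-LE assay the change gives a 2.1-fold lower number from compound 2 to compound 3 (0.33 log units; beyond the scatter). In a physicochemical assay for solubility, measured as kinetic solubility (a higher number here means a more soluble compound, a lower number a less soluble compound), compound 2 gives 2100 nM and compound 3 gives 24400 nM. In the physicochemical assay the same change moves the number the other way and by more, a large step against a modest one: the measured solubility of compound 2, 2100 nM, and of compound 3, 24400 nM, a 12-fold higher number (1.07 log units; beyond the scatter)

This single pair leaves open how far the two steps hold on other cores. It also leaves open how they would change with a methoxy group, an amine or a carboxylic acid at the chain end, or with a longer chain.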